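Adding a methoxy group to compound 1

The source may report more compounds than this note shows. Statements on the series, on what has been measured and on what is new or still open speak of the compounds shown alone.

Among the measured compounds shown here, in an ADME assay on THP-1 cells (Homo sapiens) for cytotoxicity, read by flow cytometry and propidium iodide staining, with a stated time of 72 h (on this read-out lower numbers stand for stronger inhibition and higher numbers for weaker inhibition), compound 1 `Nc1ccc2oc(-c3ccccc3F)cc(=O)c2c1` gives 44000 nM, the only exact number so far. For compound 2 `Nc1ccc2oc(-c3cccc(F)c3)cc(=O)c2c1`, this assay reports only a limit, > 125000 nM. Compound 3 `COc1c(-c2ccccc2F)oc2ccc(N)cc2c1=O` differs from compound 1 by methoxy in place of hydrogen on an aromatic carbon, ortho to a 2-fluorophenyl group (methoxy in place of hydrogen on an aromatic carbon). For the measured compounds named here, no measured step shows what this change does, so the estimated step of a 1.4-fold higher number from compound 1 to compound 3 (0.13 log units; within the scatter) is expected to stay within the usual scatter of this assay. Compound 3 is expected at 60000 nM, with an estimated range from 20000 nM to 125000 nM.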

Compound 3, half-maximal inhibitory concentration: > 125000 nM
Compound 3 ended at the assay's limit; the forecaster's own chance of this, stated with the estimate: 25%; middle value at least 2.0-fold (0.31 log units) from the limit.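

In this assay, methoxy in place of hydrogen on this aromatic carbon, ortho to a 2-fluorophenyl group, gives an at least 2.8-fold higher number from compound 1 to compound 3 (0.45 log units; beyond the scatter), so this position does respond to substitution, and the change here weakens inhibition. Compound 3 is reported only as a limit, so the step gives a minimum and its full size stays unknown, because the reading stops there: the limit of > 125000 nM in this assay, at which 2 of the 3 values shown sit.

Going by these compounds, what stays open is whether this shift belongs to methoxy itself or would follow other groups at this position. A hydroxyl group, an amine or a longer chain such as ethoxy could each behave differently.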